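Aryl in Place of Methyl on the Shared Core

The source may report more compounds than this note shows. Statements on the series, on what has been measured and on what is new or still open speak of the compounds shown alone.

Measured compounds:
compound 1 `Cc1nnn(Cc2ccc(C(F)(F)F)cc2)c1C(=O)N[C@@H](C)c1ccc(C(=O)O)cc1`: > 10000 nM
compound 2 `COc1ccc(Cn2nnc(-c3ccccc3)c2C(=O)N[C@@H](C)c2ccc(C(=O)O)cc2)cc1F`: 29.8 nM

In a functional assay on CHO cells for antagonist activity at prostaglandin E2 receptor EP4 subtype (Homo sapiens), read by calcium flux, with a stated time of 15 min (a lower number here means a stronger inhibitor, a higher number a weaker inhibitor), compound 1 is known only as a limit of the assay, > 10000 nM, as noted in the limit of > 10000 nM in this assay, at which 1 of the 2 values shown sits. Going by the values given here, compound 2 differs from compound 1 at several places, and no single step joins the two. In this assay compound 2 gives 29.8 nM. Compound 3 `Cc1ccc(-c2nnn(Cc3ccc(C(F)(F)F)cc3)c2C(=O)N[C@@H](C)c2ccc(C(=O)O)cc2)s1` alters compound 1 at one place: 5-methylthiophen-2-yl in place of methyl on an aromatic carbon. A large gain in potency is expected, an at least 120-fold lower number from compound 1 to compound 3 (2.09 log units; beyond the scatter). For compound 3 the estimate is 80 nM, expected to fall between 15 nM and 500 nM.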

Compound 3, half-maximal inhibitory concentration: 4.6 nM
Compound 3: the middle estimate sits 17-fold (1.24 log units) above what was measured, outside the stated range (below it).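

On an aromatic carbon next to the ring nitrogen, 5-methylthiophen-2-yl in place of methyl is a single change, and in this assay it gives an at least 2100-fold lower number from compound 1 to compound 3 (3.33 log units; beyond the scatter). Going by these compounds alone, compound 2 differs from compound 1 at several places, so only this step ties a gain to this position alone. The true size of the step remains a bound, since the reading for compound 1 is a limit: the limit of > 10000 nM in this assay, at which 1 of the 3 values shown sits.

The compounds shown leave open how much of the gain rests on the methyl of the thiophene. They also leave open how a cyclopropyl or an aminomethyl would read at this position.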